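A few compounds are considered here, and "the series" means these few. Any claim that something is new, unique, unknown or untested is made for them only; others in the source may bear on it.

Compound 1 `CCCCCOc1ccc2oc(/C=C/[S+](C)[O-])cc(=O)c2c1` gives 6600 nM in a functional assay on DLD-1 cells (Homo sapiens) for cytotoxicity, with a stated time of 48 h; a lower number here means a stronger inhibitor, a higher number a weaker inhibitor. Its nearest neighbour is compound 2 `C[S+]([O-])/C=C/c1cc(=O)c2ccccc2o1`, which gives 8000 nM in this assay, so the two numbers cannot be told apart. Compound 3 `C[S+]([O-])/C=C/c1cc(=O)c2cc(C#N)ccc2o1` returns only a limit, > 10000 nM, which is the limit of > 10000 nM in this assay, at which 1 of the 3 values shown sits. Compound 4 `CCCOc1ccc2oc(/C=C/[S+](C)[O-])cc(=O)c2c1` differs from compound 1 by hydrogen in place of ethyl on a saturated chain carbon, three bonds along the chain from an oxygen on an aromatic ring. For the measured compounds named here, no measured step shortens this chain; the steps of a 1.2-fold higher number from compound 1 to compound 2 (0.08 log units; within the scatter) and an at least 1.5-fold higher number from compound 1 to compound 3 (0.18 log units; that floor lies within the scatter) remove the whole pentyloxy and still stay within the scatter or at a floor inside it. A shorter chain is therefore expected to leave the number close to that of compound 1, with no step beyond the scatter. Compound 4 is estimated at 7000 nM, between 3500 nM and 14000 nM, a step of a 1.1-fold higher number from compound 1 to compound 4 (0.03 log units; within the scatter).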

Compound 4, half-maximal inhibitory concentration: 6200 nM
Compound 4: middle estimate off by 1.1-fold (0.05 log units), on the high side, and the stated range covers the measured number.
By their numbers in this assay, from the lowest: compounds 4, 1 and 2 (each within the scatter of the next). At a limit, above all of these: compound 3.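

Hydrogen in place of ethyl on a saturated chain carbon, three bonds along the chain from an oxygen on an aromatic ring, gives a 1.1-fold lower number from compound 1 to compound 4 (0.03 log units; within the scatter), the only step here that alters the chain without removing it. Propoxy in place of hydrogen gives a 1.3-fold lower number from compound 2 to compound 4 (0.11 log units; within the scatter), so in this assay neither this change in chain length nor the presence of the propoxy group separates these compounds. Propoxy in place of cyano gives an at least 1.6-fold lower number from compound 3 to compound 4 (0.20 log units; that floor lies within the scatter). This step cannot be read as a size because the value of compound 3 is a limit: the limit of > 10000 nM in this assay, at which 1 of the 4 values shown sits.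

Still open, as far as these compounds go, is whether an amine or a carboxylic acid at the end of the chain, or a longer chain, would move the number beyond the scatter.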